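From Trifluoromethyl to Dimethoxy in a Growth Inhibition Series

The compounds below may be only part of what the source reports. "The series", "measured", "known", "first", "only" and "open" are said of these compounds alone.

In a functional assay on COLO 205 cells (Homo sapiens) for inhibition, read by sulforhodamine B assay (a higher number here means a weaker inhibitor of growth, a lower number a stronger inhibitor of growth), compound 1 (`Cc1ccc2[nH]c(-c3ccc(-c4ccc(-c5ccc(N(C)C)cc5)cc4)cc3)nc2c1`) gives 9210 nM and compound 2 (`FC(F)(F)c1ccc(-c2ccc(-c3ccc(-c4nc5ccccc5[nH]4)cc3)cc2)cc1`) gives 33900 nM as the higher of the two numbers, which makes compound 2 the weaker inhibitor of growth, beyond the scatter. Compound 3 (`COc1ccc(-c2ccc(-c3ccc(-c4nc5ccccc5[nH]4)cc3)cc2)cc1OC`) carries 3,4-dimethoxyphenyl in place of 4-(trifluoromethyl)phenyl on an aromatic carbon. Among the measured compounds shown here, no measured pair isolates this exchange, and compound 1 at 9210 nM offers the only lower reference. A moderate expected step of a 2.1-fold lower number from compound 2 to compound 3 (0.33 log units; beyond the scatter) toward a lower number is estimated in this assay for this change. Compound 3 is expected at 16000 nM with 6000 nM to 40000 nM as its estimated range.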

Compound 3, concentration for 50% growth inhibition: 41200 nM
For compound 3 the middle estimate is 2.6-fold (0.41 log units) below the measured one, outside the stated range (above it).
By their numbers in this assay, from the lowest: compound 1; then compounds 2 and 3 (each within the scatter of the next).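

In this assay the exchange of 4-(trifluoromethyl)phenyl for 3,4-dimethoxyphenyl gives a 1.2-fold higher number from compound 2 to compound 3 (0.08 log units; within the scatter) so at this position the two groups are not told apart, even though only the entering group carries hydrogen-bond acceptors. Nothing available explains this result.

Compound 1 differs from compound 2 and compound 3 in more than one place, so its value cannot be assigned to any single group. From the compounds shown here alone, whether an amine or a carboxylic acid on this aromatic carbon would shift the number remains open.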